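Changing the ring amine substituent in a weak antiproliferative series

The source may hold more compounds than are shown below. What is called first, only, known or untested is meant among the compounds shown, and "the series" means these compounds.

Of the compounds shown here, three sharing one core have been tested in a functional assay on HeLa cells (Homo sapiens) for antiproliferative activity, with a stated time of 24 h; a higher number here means a weaker inhibitor, a lower number a stronger inhibitor. Compound 1 `NC(=O)c1c(NC(=O)c2ccccc2Cl)sc2c1CCN(Cc1c(Cl)cccc1Cl)C2` gives 28800 nM, compound 2 `NC(=O)c1c(NC(=O)c2ccccc2F)sc2c1CCN(Cc1c(Cl)cccc1Cl)C2` gives 33000 nM, and compound 3 `NC(=O)c1c(NC(=O)c2cccc([N+](=O)[O-])c2)sc2c1CCN(Cc1c(Cl)cccc1Cl)C2` gives 46100 nM. All three numbers sit close together: the change a 1.1-fold higher number from compound 1 to compound 2 (0.06 log units; within the scatter), the change a 1.6-fold higher number from compound 1 to compound 3 (0.20 log units; within the scatter) and the change a 1.4-fold higher number from compound 2 to compound 3 (0.15 log units; within the scatter) all stay within the scatter, so compound 2 cannot be called stronger or weaker than its two neighbours.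

Compound 4 `NC(=O)c1c(NC(=O)c2ccccc2F)sc2c1CCN(C(=S)Nc1ccccc1Cl)C2` is built from compound 2 by a different kind of change: a group of 10 heavy atoms (7 carbon, 1 nitrogen, 1 sulfur, 1 chlorine; one six-membered aromatic ring of carbon only) in place of a group of 9 heavy atoms (7 carbon, 2 chlorine; one six-membered aromatic ring of carbon only), on an amine nitrogen in a ring. Among the compounds with values here, every measured step so far alters only the group on the carbonyl carbon of the amide, and each of them stayed within the scatter. Within the data shown here, no measured step touches the amine nitrogen in the ring, so there is no direct guide for this change. With the whole set lying in one narrow band, the step of a 1.1-fold higher number from compound 2 to compound 4 (0.03 log units; within the scatter) is expected to stay small, in no particular direction. Compound 4 is therefore estimated at 35000 nM, within a range from 10000 nM to 120000 nM.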

Compound 4, half-maximal inhibitory concentration: 19400 nM
Beside the measured number, compound 4's estimate is 1.8-fold (0.26 log units) above it, and the stated range covers the measured number.
By their numbers in this assay, from the lowest: compounds 4, 1, 2 and 3 (each within the scatter of the next, the first and the last beyond it).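

Within the data shown here, this is the first look at the amine nitrogen in the ring, and in this assay the swap gives a 1.7-fold lower number from compound 2 to compound 4 (0.23 log units; within the scatter). So this position accepts a very different group without the number leaving the scatter: 2,6-dichlorobenzyl, with 0 hydrogen-bond donors and 0 hydrogen-bond acceptors, gives way to a group with 1 hydrogen-bond donor, 1 hydrogen-bond acceptor and a sulfur atom. The earlier compounds showed this insensitivity only for the group on the carbonyl carbon, and nothing measured here explains the result.

One swap cannot show whether this nitrogen is insensitive in general: a small methyl group or a chain ending in a carboxylic acid might behave differently. As far as these compounds go, it also remains open whether the same swap would give a similar result with the 2-chlorophenyl amide of compound 1.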